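The source may report more compounds than this note shows. Statements on the series, on what has been measured and on what is new or still open speak of the compounds shown alone.

Working notes on the series around the shared core of compound 3 `CNc1ncnc2c1c(-c1ccoc1)cn2[C@@H]1O[C@H](CO)[C@@H](O)[C@H]1O`. In a functional assay on K562 cells (Homo sapiens), read by MTT assay, with a stated time of 72 h (on this read-out lower numbers stand for stronger inhibition and higher numbers for weaker inhibition), compound 3 gives only a limit, > 20000 nM. Compound 1 `CNc1ncnc2c1c(-c1ccccc1)cn2[C@@H]1O[C@H](CO)[C@@H](O)[C@H]1O` carries phenyl on the same aromatic carbon. In this assay compound 1 likewise gives only a limit, > 20000 nM. The step that the two limits leave unreadable from compound 1 to compound 3 is therefore unreadable, both values sitting at the limit of > 20000 nM in this assay, at which 2 of the 3 values shown sit. Among the measured compounds shown here, compound 2 `COc1ncnc2c1c(-c1ccco1)cn2[C@@H]1O[C@H](CO)[C@@H](O)[C@H]1O`, which carries methoxy instead of the methylamino of the other two and furan-2-yl on the aromatic carbon, is the one compound with a number: in this assay compound 2 gives 60 nM.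

Compound 4 `CNc1ncnc2c1c(-c1ccco1)cn2[C@@H]1O[C@H](CO)[C@@H](O)[C@H]1O` is not yet measured. It differs from compound 3 as furan-2-yl in place of furan-3-yl on an aromatic carbon. For the measured compounds named here, no measured step rewires the furan in this way, so none bears on it directly; the only recorded step, a step that the two limits leave unreadable from compound 1 to compound 3, shows merely that phenyl and furan-3-yl both leave the methylamino compounds at the limit. Compound 2 shows that furan-2-yl sits in a compound with a strong value when methoxy is on the core, but that pair with compound 4 differs in two places and no step can be read from it. For compound 4 the expectation is a weak value, estimated at 12000 nM with a range of 800 nM to 60000 nM, most likely again reported as a limit. The expected step is an at least 1.6-fold lower number from compound 3 to compound 4 (0.22 log units; that floor lies within the scatter), small if readable at all.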

Compound 4, half-maximal inhibitory concentration: 220 nM
For compound 4 the middle estimate is 55-fold (1.74 log units) above the measured one, outside the stated range (below it).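

In this assay, this aromatic carbon of the five-membered ring discriminates sharply between the two furans: moving the attachment from furan-3-yl to furan-2-yl, with the same atoms joined differently, gives an at least 90-fold lower number from compound 3 to compound 4 (1.95 log units; beyond the scatter) and turns a limit into a number. Among the compounds shown here, replacing phenyl gives a step of the same order, an at least 90-fold lower number from compound 1 to compound 4 (1.95 log units; beyond the scatter), so among the three methylamino compounds only the one with furan-2-yl gives a readable value. With furan-2-yl kept in place, the change at the other aromatic carbon weighs far less, as methylamino in place of methoxy gives a 3.7-fold higher number from compound 2 to compound 4 (0.56 log units; beyond the scatter), so furan-2-yl goes with a readable value under both groups shown.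

The step between phenyl and furan-3-yl remains unreadable, and the data give no order for those two groups: the limit of > 20000 nM in this assay, at which 2 of the 4 values shown sit. Still open, on these data alone, is whether the effect is specific to furan-2-yl or extends to a group such as thiophen-2-yl or pyrrol-2-yl, and whether a primary amine or dimethylamino on the core would behave like methylamino or methoxy.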